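Carbamate chain size and inhibition in the shared core

The source may hold more compounds than are shown below. What is called first, only, known or untested is meant among the compounds shown, and "the series" means these compounds.

Measured so far in an assay for inhibition of serine/threonine-protein kinase PAK 4 (Homo sapiens), read by FRET and Z'-LYTE, with a stated time of 60 min, tested at 0.5 uM, in the presence of a further agent that is not named here; a lower number here means a weaker effect, a higher number a stronger effect of the compound at the concentration tested:
compound 1 `CC(C)COC(=O)N1CCN(C(=O)c2nc(Nc3cc(C4CC4)[nH]n3)c3cc(Cl)ccc3n2)C[C@H]1C` gives 0.8%
compound 2 `CC(C)C(=O)OCOC(=O)N1CCN(C(=O)c2nc(Nc3cc(C4CC4)[nH]n3)c3cc(Cl)ccc3n2)C[C@H]1C` gives 16.4%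
compound 3 `CCOC(=O)N1CCN(C(=O)c2nc(Nc3cc(C4CC4)[nH]n3)c3cc(Cl)ccc3n2)C[C@H]1C` gives 42.4%

Compound 3 stands highest of the three; compound 2 is nearest and compound 1 furthest, both steps beyond the scatter. Compound 4 `CC(C)OC(=O)N1CCN(C(=O)c2nc(Nc3cc(C4CC4)[nH]n3)c3cc(Cl)ccc3n2)C[C@H]1C` differs from compound 3 thus: methyl in place of hydrogen on a saturated chain carbon bound to an oxygen next to a carbonyl group and a saturated chain carbon. For the measured compounds named here, the step that bears most on this is a number 41.6 percentage points higher from compound 1 to compound 3 (beyond the scatter), a change at the same place; a number 15.6 percentage points higher from compound 1 to compound 2 (beyond the scatter) and a number 26 percentage points higher from compound 2 to compound 3 (beyond the scatter) point the same way, with no compound of the three going against it. Compound 4 carries isopropoxy, between ethoxy and the isobutyl chain of compound 1, so a drop beyond the scatter is expected, a number 22.4 percentage points lower from compound 3 to compound 4 (beyond the scatter), yet smaller than the whole gap back to compound 1. Compound 4 is therefore estimated at 20%, within 3% to 42%.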

Compound 4, a percentage reported as inhibition, at one concentration (the size of the read-out at that concentration, not a potency): 26.9%
Compound 4: the middle estimate sits 6.9 percentage points below what was measured; the range from low to high includes it.
By their numbers in this assay, from the lowest: compound 1; then compound 2; then compound 4; then compound 3.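

Adding methyl on the saturated chain carbon bound to the oxygen, ethoxy to isopropoxy, gives a number 15.5 percentage points lower from compound 3 to compound 4 (beyond the scatter) and shows that this single branch lowers inhibition, though less than the full change to isobutyl does. Isopropyl in place of isobutyl on the oxygen gives a number 26.1 percentage points higher from compound 1 to compound 4 (beyond the scatter) and orders the simple alkyl carbamates as ethyl, then isopropyl, then isobutyl, with inhibition falling along that series. Compound 2 goes against a plain size trend: its ((isopropylcarbonyl)oxy)methyl group stands above isobutyl, yet a number 10.5 percentage points higher from compound 2 to compound 4 (beyond the scatter) still separates it from isopropyl.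

Going by these compounds, whether methyl or an unbranched propyl chain on the oxygen would fit this order remains open. Nothing available explains these steps.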